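Pyridin-3-yl to phenyl: working notes on compound 3

The source may report more compounds than this note shows. Statements on the series, on what has been measured and on what is new or still open speak of the compounds shown alone.

Measured in a physicochemical assay for solubility, using the shake flask method, in phosphate buffer, with a stated time of 24 h, at pH 7.4 (on this read-out higher numbers stand for higher solubility and lower numbers for lower solubility), so far:
- compound 1 `CC(Sc1nc2nn(C3COC3)cc2c(=O)n1-c1ccccc1)c1ccccn1` gives 60000 nM
- compound 2 `CC(Sc1nc2c(cnn2C)c(=O)n1-c1ccccc1)c1cccnc1` gives 209000 nM

Compound 2 stands higher of the two, and its gap to compound 1 lies beyond the scatter. Compound 3 `CC(Sc1nc2c(cnn2C)c(=O)n1-c1ccccc1)c1ccccc1` differs from compound 2 by phenyl in place of pyridin-3-yl on a saturated chain carbon bound to a saturated chain carbon and a sulfur. Among the compounds with values here, no measured pair isolates this change, so the direction and size remain an expectation. The expected change in this assay is a 4.2-fold lower number from compound 2 to compound 3 (0.62 log units; beyond the scatter), a downward step beyond the scatter. For compound 3 the estimated value is 50000 nM, with an expected range from 12000 nM to 120000 nM in this estimate.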

Compound 3, solubility: 8000 nM
Estimate against measurement, compound 3: 6.3-fold (0.80 log units) above; measured number below the stated range.
By their numbers in this assay, from the lowest: compound 3; then compound 1; then compound 2.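

Phenyl in place of pyridin-3-yl on a saturated chain carbon bound to a saturated chain carbon and a sulfur gives a 26-fold lower number from compound 2 to compound 3 (1.42 log units; beyond the scatter) in this assay, and this is the only single-change pair in the series. The ring nitrogen of pyridin-3-yl gives way to carbon, with the rest of the structure unchanged, so one atom exchange at this position is enough for a large step. Nothing available explains the size of this step.

On these data alone, whether the step carries over to the core of compound 1 remains open. So does the reading for an amine or a carboxylic acid on the phenyl ring of the 1-phenylethyl group.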